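A few compounds are considered here, and "the series" means these few. Any claim that something is new, unique, unknown or untested is made for them only; others in the source may bear on it.

Measured so far:
compound 1 `C[C@@H](NS(C)(=O)=O)c1cncc(N2C(=O)c3ccc(Cl)cc3C2(C)C)c1` with 8 nM
compound 2 `CCC(=O)N[C@@H]1CCCc2c1cncc2N1C(=O)c2ccc(Cl)cc2[C@H]1C` with 66 nM

Of the compounds shown here, two have been measured in an assay on cells for inhibition of cytochrome P450 11B2, mitochondrial (Homo sapiens), read by HTRF; on this read-out higher numbers stand for weaker inhibition and lower numbers for stronger inhibition. Compound 1 gives 8 nM, the lower of the two numbers. Compound 2 gives 66 nM, a number far enough above that of compound 1 to lie beyond the usual scatter of repeated measurements. Compound 1 thus stands as the stronger inhibitor of the two.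

The next compound to be measured is compound 3 `CC1(C)c2cc(Cl)ccc2C(=O)N1c1cccnc1`. It differs from compound 1 in one place: a hydrogen atom in place of a group of 7 heavy atoms (3 carbon, 1 nitrogen, 2 oxygen, 1 sulfur; no ring), on an aromatic carbon. A group of 7 heavy atoms, carrying 1 hydrogen-bond donor and 2 hydrogen-bond acceptors and 1 defined stereocentre, is taken away from an aromatic carbon of a six-membered aromatic ring with 1 nitrogen, and only a hydrogen atom sits there instead. Going by the values given here, no pair of measured compounds shows this kind of change, so the size of the step can only be guessed.

Taking away a group of this size is expected to cost potency, so the step from compound 1 to compound 3 is estimated as an upward move, a 25-fold higher number from compound 1 to compound 3 (1.40 log units; beyond the scatter), beyond the scatter. Compound 3 is therefore expected to give about 200 nM, within a range from 40 nM to 1500 nM.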

Compound 3, half-maximal inhibitory concentration: 108 nM
Estimate against measurement, compound 3: 1.9-fold (0.27 log units) above; the range from low to high includes it.
By their numbers in this assay, from the lowest: compound 1; then compounds 2 and 3 (each within the scatter of the next).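

In this assay, going by these compounds alone, putting a hydrogen atom in place of the group of 7 heavy atoms gives a 14-fold higher number from compound 1 to compound 3 (1.13 log units; beyond the scatter) and counts as a large step, the first reading of what this place on the six-membered aromatic ring with 1 nitrogen is worth. The group therefore adds clearly to inhibition in this series, yet it is not needed for inhibition to be measured at all, since compound 3 still gives 108 nM without it. The measurements carry no separate evidence on what lies behind the step.

From the compounds shown here alone, the whole group leaves in a single change, so it remains open how much of the step belongs to its hydrogen-bond donor, its hydrogen-bond acceptors or its defined stereocentre, and whether the opposite arrangement at that stereocentre would give the same number. Going by these compounds, it also remains open whether a much smaller group on this aromatic carbon, such as a single methyl, an amine or a carboxylic acid, would recover part of the difference between compound 3 and compound 1.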